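From 4-Methylphenyl to 4-Nitrophenyl: An Expected Small Step

This account rests on a few compounds, and the source may have more. Where it says the series, first, only, none or still open, it means among the compounds named here.

Of the compounds shown here, three sharing one core have been measured in a functional assay on MCF7 cells (Homo sapiens) for inhibition, read by sulforhodamine B assay, with a stated time of 72 h; on this read-out higher numbers stand for weaker inhibition and lower numbers for stronger inhibition. Compound 1 (`Cc1ccc(C2=Nn3c(nnc3C(C)c3ccc(CC(C)C)cc3)SC2)cc1`) gives 6300 nM. Compound 2 (`CC(c1ccc(-c2ccccc2)c(F)c1)c1nnc2n1N=C(c1ccc(OC(F)(F)F)cc1)CS2`) gives 4800 nM, which lies within the scatter of compound 1. Compound 3 (`COc1ccc2cc(C(C)c3nnc4n3N=C(c3ccc(Cl)cc3Cl)CS4)ccc2c1`) gives 14600 nM, which lies beyond the scatter of compound 1, on the side of weaker inhibition.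

Compound 4 (`CC(C)Cc1ccc(C(C)c2nnc3n2N=C(c2ccc([N+](=O)[O-])cc2)CS3)cc1`) has not yet been measured. It differs from compound 1 in one place, with nitro in place of methyl on an aromatic carbon, para to a large group: nitro in place of methyl on an aromatic carbon. Among the compounds with values here, no two measured compounds differ in only one place, so the data give no direct reading of this change. Compound 2, at 4800 nM, differs from compound 1 in more than one place and still falls within its scatter, so no step beyond the scatter is expected in this assay. The expected step is a 1.1-fold higher number from compound 1 to compound 4 (0.05 log units; within the scatter), which stays within the scatter. For compound 4 the estimated value is 7000 nM, with an expected range from 3000 nM to 16000 nM.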

Compound 4, half-maximal inhibitory concentration: "not active" (no number reported)
Compound 4 has no reported number here; the estimate stays without a comparison.
By their numbers in this assay, from the lowest: compounds 2 and 1 (each within the scatter of the next); then compound 3.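

Within the data shown here, compound 4 gives "not active" (no number reported) and so no step from compound 1 can be read. The compounds shown leave open what the change from 4-methylphenyl to 4-nitrophenyl does to inhibition. No outside evidence bears on this result.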